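Solubility Expected to Rise with a Carboxypiperidine Group

The compounds below may be only part of what the source reports. "The series", "measured", "known", "first", "only" and "open" are said of these compounds alone.

Compound 1 `CCNC(=O)Nc1nc2cc(-c3cccnc3)cc(-c3ccccn3)c2s1` carries a urea on the shared core and two aromatic rings with one nitrogen each. Among the compounds with values here, in a physicochemical assay for solubility, read by turbidimetry, in phosphate buffer, with a stated time of 24 h, at pH 7.4 (a higher number here means a more soluble compound, a lower number a less soluble compound), compound 1 gives 6.25 ug/mL, the only plain number among the values shown. Compound 2 `CCNC(=O)Nc1nc2cc(-c3cnc(N4CCC(C(=O)O)(S(C)(=O)=O)CC4)nc3)cc(-c3ccccn3)c2s1` is a relative bearing a carboxylic acid on a piperidine. In this assay compound 2 reports only a limit, > 800 ug/mL. That limit is described as the limit of > 800 ug/mL in this assay, at which 1 of the 2 values shown sits. Compound 3 `CCNC(=O)Nc1nc2cc(-c3ccc(N4CCC(C)(C(=O)O)CC4)nc3)cc(-c3ccccn3)c2s1` has not yet been measured. It differs from compound 1 by 4-carboxy-4-methylpiperidin-1-yl in place of hydrogen on an aromatic carbon. No step between measured compounds is shown for this change. The expected step is a 64-fold higher number from compound 1 to compound 3 (1.81 log units; beyond the scatter), well beyond the scatter and toward greater solubility. This expectation rests on the fact that compound 2 in this assay gives the limit > 800 ug/mL. Compound 3 is accordingly expected at 400 ug/mL, within 100 ug/mL to 800 ug/mL.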

Compound 3, solubility: > 800 ug/mL
Compound 3: no number, only a limit; the forecaster's own chance of this, stated with the estimate: 45%; middle value at least 2.0-fold (0.30 log units) from the limit.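

Within the data shown here, at this position, on an aromatic carbon of a six-membered aromatic ring with 1 nitrogen, next to the ring nitrogen and para to a large group, 4-carboxy-4-methylpiperidin-1-yl in place of hydrogen gives an at least 120-fold higher number from compound 1 to compound 3 (2.10 log units; beyond the scatter) in this assay, the first step that can be read for this change. In that assay compound 3 gives > 800 ug/mL, which is a limit and not a number. The step therefore has a lower bound but no upper one, and most of the values shown end at the same limit: the limit of > 800 ug/mL in this assay, at which 2 of the 3 values shown sit.

The compounds shown leave open whether the step belongs to the carboxylic acid or to the piperidine ring; a plain piperidine, a methyl ester or a primary amide at this position would separate the two. Going by these compounds, the part played by the methyl group on the piperidine also stays open.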